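The source may report more compounds than this note shows. Statements on the series, on what has been measured and on what is new or still open speak of the compounds shown alone.

Three compounds share a scaffold in which a carbonyl ring is joined through a double bond to a chlorinated or brominated phenyl ring. Compound 1 `O=C1/C(=C/c2cccc(Cl)c2)Cc2ccccc21` carries a chlorine on that phenyl ring; in a functional assay on MOLT-4 cells (Homo sapiens) for inhibition (a lower number here means a stronger inhibitor, a higher number a weaker inhibitor), compound 1 gives 50900 nM. Compound 2 `O=C1/C(=C/c2cccc(Br)c2)Cc2ccccc21` carries a bromine instead, and in this assay compound 2 gives 173000 nM. The step of a 3.4-fold higher number from compound 1 to compound 2 (0.53 log units; beyond the scatter) rests on one change, (bromo in place of chloro on an aromatic carbon).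

Compound 3 `O=C1/C(=C/c2cccc(Cl)c2)CCCc2ccccc21` has a larger core; how its core differs from that of compound 1 is not broken down here. In this assay compound 3 gives 23800 nM, the lowest of the three numbers.

Compound 4 `O=C1/C(=C/c2cccc(Br)c2)CCCc2ccccc21` has not been measured. It differs from compound 3 by the same kind of change, (bromo in place of chloro on an aromatic carbon), at a place described in the same words as for the pair of compound 1 and compound 2. Because compound 3 gives 23800 nM as the starting point for the same change, the step of a 2.7-fold higher number from compound 3 to compound 4 (0.44 log units; beyond the scatter) is expected to resemble the step of a 3.4-fold higher number from compound 1 to compound 2 (0.53 log units; beyond the scatter). Compound 4 is therefore estimated at 65000 nM, with a likely range from 25000 nM to 160000 nM.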

Compound 4, half-maximal inhibitory concentration: 17100 nM
Compound 4: middle estimate off by 3.8-fold (0.58 log units), on the high side; measured number below the stated range.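

In this assay bromo in place of chloro on the larger core gives a 1.4-fold lower number from compound 3 to compound 4 (0.14 log units; within the scatter) and so leaves the two compounds with no real separation. The result shows that, in this small set, the size of the step seen on one core cannot simply be carried over to the other, but it does not show what in the cores makes the steps differ or how the change would behave on a third core. The two steps, each a single halogen swap, do not agree: the same change on two cores in this assay, a 3.4-fold higher number (0.53 log units; beyond the scatter) from compound 1 to compound 2 and a 1.4-fold lower number (0.14 log units; within the scatter) from compound 3 to compound 4, 4.7-fold (0.67 log units) apart, beyond the scatter of two such steps

The compounds shown hold only chloro and bromo at this place on the aromatic ring, so the effect of a fluoro group, a methoxy group or an amine there remains open. On these data alone, whether any of these groups would also give steps that differ between the two cores stays open as well.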